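The compounds below may be only part of what the source reports. "The series", "measured", "known", "first", "only" and "open" are said of these compounds alone.

Compound 3 `O=C1COCCN1c1ccc(Nc2nc(Cl)nc(Nc3ccc(Cl)cc3)n2)cc1` gives 79% in a functional assay on the whole organism (strain Swiss) for inhibition, with Mus musculus as the target, with a stated time of 30 min, at a dose of 5 mg/kg by the intraperitoneal route (on this read-out higher numbers stand for a stronger effect at the one dose given and lower numbers for a weaker effect), the highest of the three numbers, though compound 2 `O=C1COCCN1c1ccc(Nc2nc(Cl)nc(Nc3ccccc3)n2)cc1` gives 76% and the two lie within the usual scatter of each other, as the step of a number 3 percentage points higher from compound 2 to compound 3 (within the scatter) shows. Compound 1 `O=C1COCCN1c1ccc(Nc2nc(Cl)nc(NC3CCCCC3)n2)cc1` gives 56%, and the step of a number 23 percentage points higher from compound 1 to compound 3 (beyond the scatter). Compound 4 `O=C1COCCN1c1ccc(Nc2nc(Cl)nc(Nc3ccc(O)cc3)n2)cc1` differs from compound 3 by hydroxy in place of chloro on an aromatic carbon. Among the measured compounds shown here, the one step that touches the same place, a number 3 percentage points higher from compound 2 to compound 3 (within the scatter), shows that changing the group on this aromatic carbon hardly moved the number, but no measured compound carries a hydroxy, so the expected step of a number 9 percentage points lower from compound 3 to compound 4 (within the scatter) is small, with no clear direction beyond the scatter. Compound 4 is therefore estimated at 70%, within a range from 50% to 88%.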

Compound 4, a percentage reported as inhibition, in the whole organism at one dose (the size of the read-out at that dose, not a potency): 56%
Beside the measured number, compound 4's estimate is 14 percentage points above it; the measured number falls inside the stated range.
By their numbers in this assay, from the lowest: compounds 1 and 4 (each within the scatter of the next); then compounds 2 and 3 (each within the scatter of the next).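

On this aromatic carbon the group does matter in this assay: hydroxy in place of chloro gives a number 23 percentage points lower from compound 3 to compound 4 (beyond the scatter) and hydroxy in place of hydrogen gives a number 20 percentage points lower from compound 2 to compound 4 (beyond the scatter) while chloro in place of hydrogen had stayed within the scatter. With 4-hydroxyphenyl in place of cyclohexyl there is no change at the digits printed from compound 1 to compound 4 (within the scatter) so the hydroxy takes away the gain seen with the plain phenyl. Nothing available explains why the hydroxy lowers the number. As far as these compounds go, whether a methoxy or an amine on this carbon would behave like the hydroxy or like the chloro remains open.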